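This account rests on a few compounds, and the source may have more. Where it says the series, first, only, none or still open, it means among the compounds named here.

Working notes on the series.

Of the compounds shown here, two carry a measured number so far. Compound 1 `COc1cc(-c2nn(-c3cccc(NC(=O)Nc4cc(C(F)(F)F)cc(C(F)(F)F)c4)c3)cc2-c2ccncc2)ccc1Cl` and compound 2 `COc1cc(-c2nn(-c3cccc(NC(=O)Nc4ccc(Cl)c(Cl)c4)c3)cc2-c2ccncc2)ccc1Cl` share the same core and differ only in the aryl half of the urea. In a functional assay on SF-295 cells (Homo sapiens) for inhibition, read by sulforhodamine B assay, with a stated time of 48 h (on this read-out lower numbers stand for stronger inhibition of growth and higher numbers for weaker inhibition of growth), compound 1 gives 399 nM, and in this assay compound 2 gives 691 nM. Compound 2 carries the higher of the two numbers, but its separation from compound 1 lies within the scatter of this kind of measurement, so the two cannot be placed in any order on present evidence.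

Compound 3 `COc1cc(-c2nn(-c3cccc(NC(=O)c4ccc(Cl)c(C(F)(F)F)c4)c3)cc2-c2ccncc2)ccc1Cl` has not been measured. It departs from compound 2 by one change: 4-chloro-3-(trifluoromethyl)phenyl in place of (3,4-dichlorophenyl)amino on a carbonyl carbon. Going by the values given here, no step between two measured compounds matches this change, so there is nothing to calibrate it against; the two values in hand only fix the level at which this part of the series sits. For lack of a comparable step, the expectation for compound 3 rests on that level alone, with a wide range allowed and no direction asserted beyond the scatter, the step from compound 2 being put at a 1.4-fold higher number from compound 2 to compound 3 (0.16 log units; within the scatter). On that basis compound 3 is estimated at 1000 nM in this assay, within 300 nM to 3500 nM.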

Compound 3, concentration for 50% growth inhibition: 1380 nM
Beside the measured number, compound 3's estimate is 1.4-fold (0.14 log units) below it, within the range that was stated.
By their numbers in this assay, from the lowest: compounds 1, 2 and 3 (each within the scatter of the next, the first and the last beyond it).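

Going by these compounds alone, this is the first change at the carbonyl carbon that removes the amino link of the urea and sets an aryl ring directly on that carbon, leaving an amide-type nitrogen on its other side. In this assay, within the data shown here, the replacement of (3,4-dichlorophenyl)amino by 4-chloro-3-(trifluoromethyl)phenyl gives a step within the scatter (a 2.0-fold higher number from compound 2 to compound 3 (0.30 log units; within the scatter)), so compound 2 and compound 3 cannot be placed in any order, even though the hydrogen-bond donor counted in the leaving group has no counterpart in the entering group. No measurement in hand bears on the reason for this result.

The step alters the link and the ring substituents together, so the compounds shown leave the contribution of each unresolved; a 3,4-dichlorophenyl group set directly on the carbonyl carbon, or a (4-chloro-3-(trifluoromethyl)phenyl)amino group in the same place, would separate the two. Also open, going by these compounds, is how this position responds to groups other than substituted aryl rings, such as a morpholine or a short alkyl amine on the carbonyl carbon.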